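From 4-ethylphenyl to 4-isopropylphenyl: one more methyl

This account rests on a few compounds, and the source may have more. Where it says the series, first, only, none or still open, it means among the compounds named here.

Measured so far in a toxicity assay on PC-12 cells (Rattus norvegicus) for cytotoxicity, read by MTT assay; a lower number here means a stronger inhibitor, a higher number a weaker inhibitor:
compound 1 `Cc1ccc(-n2nc(-c3ccc(C(F)(F)F)cc3O)nc2-c2ccccc2O)cc1`: 113000 nM
compound 2 `CCc1ccc(-n2nc(-c3ccc(C(F)(F)F)cc3O)nc2-c2ccccc2O)cc1`: 147000 nM

Compound 2 gives 147000 nM, which lies within the scatter of compound 1, so the two cannot be ordered on these numbers. The next compound, compound 3 `CC(C)c1ccc(-n2nc(-c3ccc(C(F)(F)F)cc3O)nc2-c2ccccc2O)cc1`, keeps the shared core and changes only the chain: methyl in place of hydrogen on a saturated chain carbon bound to an aromatic carbon and a saturated chain carbon. In words, this is methyl in place of hydrogen on a saturated chain carbon bound to an aromatic carbon and a saturated chain carbon, so that ethyl becomes isopropyl.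

For the measured compounds named here, only one measured step bears on this change, the similar placing of methyl in place of hydrogen on a saturated chain carbon bound to an aromatic carbon: a 1.3-fold higher number from compound 1 to compound 2 (0.11 log units; within the scatter). Going by the values given here, a single step of that size sets no trend, and no branched chain has yet been measured. No step beyond the scatter is therefore expected in this assay, and no direction can be favoured. The expected step is a 1.0-fold higher number from compound 2 to compound 3 (0.01 log units; within the scatter). Compound 3 is estimated at 150000 nM, with an expected range from 80000 nM to 280000 nM.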

Compound 3, half-maximal inhibitory concentration: 144000 nM
For compound 3 the middle estimate is 1.0-fold (0.02 log units) above the measured one; low and high end bracket the measured number.
By their numbers in this assay, from the lowest: compounds 1, 3 and 2 (each within the scatter of the next).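

In this assay the branched isopropyl chain, the only branched chain among these compounds, gives a 1.0-fold lower number from compound 2 to compound 3 (0.01 log units; within the scatter) and so shows that adding methyl on the saturated chain carbon bound to an aromatic carbon and a saturated chain carbon leaves the number within the scatter. The wider comparison gives a 1.3-fold higher number from compound 1 to compound 3 (0.11 log units; within the scatter) for isopropyl in place of methyl on an aromatic carbon, so methyl, ethyl and isopropyl at this position cannot be ordered, and both a straight extension and a branch at this carbon now stand within the scatter in this small set of compounds. No measurement here offers an explanation of this result.

The compounds shown leave open whether a longer chain, a tert-butyl group, an amine or a carboxylic acid at this position would give a step beyond the scatter. They also leave open what the hydroxyl groups and the trifluoromethyl group contribute to the numbers, since these stay the same in compound 1, compound 2 and compound 3.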